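A few compounds are considered here, and "the series" means these few. Any claim that something is new, unique, unknown or untested is made for them only; others in the source may bear on it.

Compound 2 `O=C(OC1(C(=O)Nc2ccc([N+](=O)[O-])cc2)CCCCC1)c1ccccc1` holds the lower of the two numbers in an ADME assay on WI-38 cells (Homo sapiens) for inhibition, read by MTT assay, with a stated time of 72 h; a higher number here means a weaker inhibitor, a lower number a stronger inhibitor: compound 2 gives 246 nM, while compound 1 `O=C(OC1(C(=O)Nc2ccc([N+](=O)[O-])cc2)CCCCC1)c1ccc(Br)cc1` gives 523 nM. For the measured compounds named here, the only measured step, a 2.1-fold lower number from compound 1 to compound 2 (0.33 log units; beyond the scatter), altered the group on an aromatic carbon and left the benzoyloxy group untouched. Going by the values given here, compound 3 `CCC(=O)OC1(C(=O)Nc2ccc([N+](=O)[O-])cc2)CCCCC1` differs from compound 2 by ethyl in place of phenyl on a carbonyl carbon, a change that no measured step addresses directly. Among the compounds with values here, with only one modest step elsewhere to go on, at most a modest move is expected, a 1.6-fold higher number from compound 2 to compound 3 (0.21 log units; within the scatter). Compound 3 is therefore expected to give 400 nM, within 150 nM to 1100 nM.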

Compound 3, half-maximal inhibitory concentration: 44.6 nM
Estimate against measurement, compound 3: 9.0-fold (0.95 log units) above, and the stated range ends above it.
By their numbers in this assay, from the lowest: compound 3; then compound 2; then compound 1.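

For the compounds shown here, at this carbonyl carbon, the earlier compounds had varied only a substituent on the aromatic ring, whereas here the ring itself is replaced. In this assay ethyl in place of phenyl gives a 5.5-fold lower number from compound 2 to compound 3 (0.74 log units; beyond the scatter) and ethyl in place of 4-bromophenyl gives a 12-fold lower number from compound 1 to compound 3 (1.07 log units; beyond the scatter) so an aromatic ring at this place is not required for a low number among these compounds. Nothing available explains this change. From the compounds shown here alone, whether a longer chain such as butyl would keep the number this low stays open. So does the effect of an amine on the chain.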